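The compounds below may be only part of what the source reports. "The series", "measured", "known", "first", "only" and "open" are said of these compounds alone.

Compounds measured in a functional assay on MGC-803 cells (Homo sapiens) for antiproliferative activity, read by MTT assay, with a stated time of 48 h; on this read-out higher numbers stand for weaker inhibition and lower numbers for stronger inhibition:

- compound 1 `CCCCCCCCCCn1cc(COC[C@@H]2OC[C@H](N)[C@H]2O)nn1`: 57400 nM
- compound 2 `CCCCCCCCCCCCn1cc(COC[C@@H]2OC[C@H](N)[C@H]2O)nn1`: 115000 nM
- compound 3 `CCCCCCCCCCCCCCCCn1cc(COC[C@@H]2OC[C@H](N)[C@H]2O)nn1`: 5340 nM

Compound 3 has the lowest number of the three and so is the strongest inhibitor in this assay, with 5340 nM. Its gaps to the other two are both beyond the scatter.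

Compound 4 `CCCCCCCCCCCCCCCCCCn1cc(COC[C@@H]2OC[C@H](N)[C@H]2O)nn1` has one change from compound 3: ethyl in place of hydrogen on a saturated chain carbon, ten or more bonds along the chain from an aromatic nitrogen. This places ethyl in place of hydrogen on a saturated chain carbon, ten or more bonds along the chain from an aromatic nitrogen.

Among the compounds with values here, the closest precedent is the same ethyl change in a 2.0-fold higher number from compound 1 to compound 2 (0.30 log units; within the scatter), which stayed within the scatter. Larger extensions of the chain behaved differently, with an 11-fold lower number from compound 1 to compound 3 (1.03 log units; beyond the scatter) and a 22-fold lower number from compound 2 to compound 3 (1.33 log units; beyond the scatter). These three steps do not form a steady trend with chain length, as the drop appears only at compound 3. They offer no firm basis for a further large gain or loss, so the ethyl precedent carries the most weight, with a slight allowance for a weaker result.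

Within the data shown here, the expected change is small, an estimated 1.9-fold higher number from compound 3 to compound 4 (0.27 log units; within the scatter), and no step clearly beyond the scatter is predicted. For compound 4 the estimated value is 10000 nM, with an expected range of 2500 nM to 50000 nM.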

Compound 4, half-maximal inhibitory concentration: 3110 nM
Compound 4: the middle estimate sits 3.2-fold (0.51 log units) above what was measured, within the range that was stated.
By their numbers in this assay, from the lowest: compounds 4 and 3 (each within the scatter of the next); then compounds 1 and 2 (each within the scatter of the next).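

In this assay, the ethyl change on the chain of compound 3 gives a 1.7-fold lower number from compound 3 to compound 4 (0.23 log units; within the scatter), so the low number seen at compound 3 is not a lone value: compound 4 stands with it, and the two form a group apart from compounds 1 and 2. The separation from the shorter chains holds for compound 4 as well, with a 37-fold lower number from compound 2 to compound 4 (1.57 log units; beyond the scatter) and an 18-fold lower number from compound 1 to compound 4 (1.27 log units; beyond the scatter), although the pattern is a jump and not a steady fall with chain length, as the step to compound 2 stays within the scatter. The ethyl change has now been read on two cores, and its effect depends on the chain it extends, though neither step alone lies beyond the scatter: the same change on two cores in this assay, a 2.0-fold higher number (0.30 log units; within the scatter) from compound 1 to compound 2 and a 1.7-fold lower number (0.23 log units; within the scatter) from compound 3 to compound 4, 3.4-fold (0.54 log units) apart, beyond the scatter of two such steps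

The compounds shown leave open whether a longer chain than that of compound 4 would hold this level or lose it. They also leave open what a terminal hydroxyl on the chain, or a carboxylic acid in place of the amine on the shared core, would do to the number in this assay.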